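Trimming the sulfonyl tail of a dioxane carboxamide series

The compounds below may be only part of what the source reports. "The series", "measured", "known", "first", "only" and "open" are said of these compounds alone.

Compounds measured in an assay on isolated protein for inhibition of 5-hydroxytryptamine receptor 4 (Homo sapiens); a lower number here means a stronger inhibitor, a higher number a weaker inhibitor:
compound 1, `CC(C)N1CCN(S(=O)(=O)CCCN2CCC(CNC(=O)c3cccc4c3OCCO4)CC2)CC1`, gives 0.0316 nM;
compound 2, `CC1(C)CCN(S(=O)(=O)CCCN2CCC(CNC(=O)c3cccc4c3OCCO4)CC2)CC1`, gives 0.126 nM;
compound 3, `CS(=O)(=O)N1CCN(S(=O)(=O)CCCN2CCC(CNC(=O)c3cccc4c3OCCO4)CC2)CC1`, gives 0.316 nM.

Compound 2 stands second highest of the three numbers: the nearest is compound 3 with a 2.5-fold higher number from compound 2 to compound 3 (0.40 log units; beyond the scatter), and the furthest is compound 1, from which a 4.0-fold higher number from compound 1 to compound 2 (0.60 log units; beyond the scatter) leads to compound 2. The unmeasured compound 4, `CCCCN1CCC(CNC(=O)c2cccc3c2OCCO3)CC1`, differs from compound 2 in one place: methyl in place of (4,4-dimethylpiperidin-1-yl)sulfonyl on a saturated chain carbon, three bonds along the chain from an amine nitrogen in a ring.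

The measured steps all concern exchanges of the terminal group on the sulfonyl sulfur or on the ring nitrogen within it, with a 4.0-fold higher number from compound 1 to compound 2 (0.60 log units; beyond the scatter), a 10-fold higher number from compound 1 to compound 3 (1.00 log units; beyond the scatter) and a 2.5-fold higher number from compound 2 to compound 3 (0.40 log units; beyond the scatter); none of them removes the whole group. Since every variation of that group moved the number only modestly, its complete loss is expected to cost more, but not to abolish binding, given how strong the shared core of compound 2 already is. Compound 4 is therefore estimated at 1 nM, within 0.2 nM to 6 nM, a weakening step of a 7.9-fold higher number from compound 2 to compound 4 (0.90 log units; beyond the scatter) being expected.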

Compound 4, inhibition constant: 0.794 nM
Beside the measured number, compound 4's estimate is 1.3-fold (0.10 log units) above it; measured number inside the range.
By their numbers in this assay, from the lowest: compound 1; then compound 2; then compound 3; then compound 4.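

The earlier compounds shown here only exchanged the end of the sulfonyl tail, whereas compound 4 loses the entire (4,4-dimethylpiperidin-1-yl)sulfonyl group, and methyl enters on the saturated chain carbon, with a 6.3-fold higher number from compound 2 to compound 4 (0.80 log units; beyond the scatter) in this assay. This shows that the group adds to binding at this position but is not needed for it, since a strong inhibitor remains without it. The cost of losing the whole group is no larger than that of one exchange within the tail, a 10-fold higher number from compound 1 to compound 3 (1.00 log units; beyond the scatter), although no measured information on the cause of this is available here.

As far as these compounds go, it remains open whether the gain comes from the sulfonyl unit or from the ring attached to it. A methylsulfonyl group or a carboxylic acid on that chain carbon could separate these two parts.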